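The source may hold more compounds than are shown below. What is called first, only, known or untested is meant among the compounds shown, and "the series" means these compounds.

In a functional assay on HepG2 cells (Homo sapiens) for antiproliferative activity, read by MTT assay, with a stated time of 48 h (a lower number here means a stronger inhibitor, a higher number a weaker inhibitor), three compounds sharing one core have been measured. Compound 1 `CC(=O)N1N=C(c2ccc3ccccc3c2)OC1c1cccc(Br)c1` gives 1.68 ug/mL and compound 2 `CC(=O)N1N=C(c2ccc3ccccc3c2)OC1c1ccccc1Cl` gives 4.32 ug/mL in this test, while compound 3 `CC(=O)N1N=C(c2ccc3ccccc3c2)OC1c1ccccc1[N+](=O)[O-]` gives 12.3 ug/mL as the highest number of the three, making it the weakest inhibitor here. Compound 4 `CC(=O)N1N=C(c2ccc3ccccc3c2)OC1c1ccsc1` carries thiophen-3-yl in place of 2-nitrophenyl on a saturated ring carbon. For the measured compounds named here, no measured compound holds thiophen-3-yl, so the only guides are the two rises that end at 2-nitrophenyl: a 2.8-fold higher number from compound 2 to compound 3 (0.45 log units; beyond the scatter) and a 7.3-fold higher number from compound 1 to compound 3 (0.86 log units; beyond the scatter). A modest fall in this assay is therefore expected, namely a 2.5-fold lower number from compound 3 to compound 4 (0.39 log units; beyond the scatter) as an estimate. For compound 4 the estimated value is 5 ug/mL, with an expected range from 1.7 ug/mL to 15 ug/mL.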

Compound 4, half-maximal inhibitory concentration: 6.82 ug/mL
Compound 4: middle estimate off by 1.4-fold (0.13 log units), on the low side; the measured number falls inside the stated range.
By their numbers in this assay, from the lowest: compound 1; then compounds 2, 4 and 3 (each within the scatter of the next, the first and the last beyond it).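

In this assay, the five-membered thiophen-3-yl ring cannot be told apart from either six-membered ring bearing a group at its 2-position: a 1.8-fold lower number from compound 3 to compound 4 (0.26 log units; within the scatter) and a 1.6-fold higher number from compound 2 to compound 4 (0.20 log units; within the scatter) both lie within the scatter. Only 3-bromophenyl remains clearly separate, with a 4.1-fold higher number from compound 1 to compound 4 (0.61 log units; beyond the scatter). Nothing available here explains these differences.

Still open, from the compounds shown here alone, is how an unsubstituted phenyl or thiophen-2-yl ring would compare at this saturated ring carbon. Also open, going by these compounds, is whether an amine or a longer alkyl chain could take the place of an aromatic ring there.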